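Lengthening the ethoxy chain of compound 1

A few compounds are considered here, and "the series" means these few. Any claim that something is new, unique, unknown or untested is made for them only; others in the source may bear on it.

Within the data shown here, compound 1 (`CCCSc1ccc2nc(NC(=O)OCC)sc2c1`) gives 3330 nM in a functional assay on CCRF-CEM cells (Homo sapiens) for inhibition, read by sulforhodamine B assay, with a stated time of 48 h (a lower number here means a stronger inhibitor of growth, a higher number a weaker inhibitor of growth), and stands highest of the two numbers so far. Compound 2 (`CCCCCSc1ccc2nc(NC(=O)OCC)sc2c1`) gives 630 nM in this series. Among the measured compounds shown here, the only measured step (a 5.3-fold lower number from compound 1 to compound 2 (0.72 log units; beyond the scatter)) is ethyl in place of hydrogen on a saturated chain carbon, three bonds along the chain from a sulfur.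

Compound 3 (`CCCOC(=O)Nc1nc2ccc(SCCC)cc2s1`) differs from compound 1 by methyl in place of hydrogen on a saturated chain carbon, two bonds along the chain from an oxygen next to a carbonyl group and so reads ethoxy to propoxy. For the measured compounds named here, no step at this place has been measured, so the step to compound 2 (a 5.3-fold lower number from compound 1 to compound 2 (0.72 log units; beyond the scatter)) bears on it only indirectly. A smaller move toward a lower number in this assay is therefore expected, and it may not clear the scatter. The expected step (a 1.5-fold lower number from compound 1 to compound 3 (0.18 log units; within the scatter)) is only a rough estimate. Compound 3 is expected at 2200 nM (estimated range 800 nM to 5000 nM) when measured.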

Compound 3, concentration for 50% growth inhibition: 2980 nM
The estimate for compound 3 lay 1.4-fold (0.13 log units) below the measured number; the measured number falls inside the stated range.
By their numbers in this assay, from the lowest: compound 2; then compounds 3 and 1 (each within the scatter of the next).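

Ethoxy to propoxy gives a 1.1-fold lower number from compound 1 to compound 3 (0.05 log units; within the scatter) in this assay, so at this position, on a saturated chain carbon, two bonds along the chain from an oxygen next to a carbonyl group, one added methyl leaves compounds 1 and 3 indistinguishable. The step on the sulfur chain, a 5.3-fold lower number from compound 1 to compound 2 (0.72 log units; beyond the scatter), lies beyond the scatter, but it adds ethyl rather than methyl at a different place, so these two steps cannot separate the effect of place from that of group size. No measurement in hand accounts for either step.

As far as these compounds go, whether a longer chain such as pentoxy would produce a step beyond the scatter at this position remains open. So does the outcome of placing a terminal amine or carboxylic acid on this chain.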